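Ring substituent variation on a shared core

A few compounds are considered here, and "the series" means these few. Any claim that something is new, unique, unknown or untested is made for them only; others in the source may bear on it.

Measured so far in an assay on isolated protein for inhibition of Ectonucleotide pyrophosphatase/phosphodiesterase family member 1 (Homo sapiens), tested at 10 uM; on this read-out higher numbers stand for more inhibition at the one concentration tested (going by the name of the read-out) and lower numbers for less inhibition:
compound 1 `Cc1ccc(NC(=O)CSc2nc3cccnc3[nH]2)cc1C`: 11%
compound 2 `COc1cccc(NC(=O)CSc2nc3cccnc3[nH]2)c1`: 30%
compound 3 `COc1cc(NC(=O)CSc2nc3cccnc3[nH]2)cc(OC)c1`: 38%

Compound 2 stands second highest of the three numbers; its nearest neighbour lies within the scatter, by a number 8 percentage points higher from compound 2 to compound 3 (within the scatter), while compound 1 lies furthest, beyond the scatter. Compound 4 `CC(=O)c1cccc(NC(=O)CSc2nc3cccnc3[nH]2)c1` is not yet measured. It differs from compound 2 by acetyl in place of methoxy on an aromatic carbon. Among the measured compounds shown here, no measured step exchanges one group for another on that ring; the single step, a number 8 percentage points higher from compound 2 to compound 3 (within the scatter), only adds a methoxy and stays within the scatter. Nothing shown therefore points in either direction, and the step of no change at the digits printed from compound 2 to compound 4 (within the scatter) is expected to stay within the scatter. Compound 4 is estimated at 30% in this assay, between 10% and 50%.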

Compound 4, a percentage reported as inhibition, at one concentration (the size of the read-out at that concentration, not a potency): 50%
The estimate for compound 4 lay 20 percentage points below the measured number; the measured number falls inside the stated range.
By their numbers in this assay, from the lowest: compound 1; then compounds 2 and 3 (each within the scatter of the next); then compound 4.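

In this assay, acetyl in place of methoxy on an aromatic carbon meta to a large group gives a number 20 percentage points higher from compound 2 to compound 4 (beyond the scatter) and so moves the read-out beyond the scatter. Among the compounds shown here, the earlier step on this ring, a number 8 percentage points higher from compound 2 to compound 3 (within the scatter), only added a methoxy, so this is the first exchange of one group for another there and the first sign that the read-out responds to the group at this place. Nothing shown gives a reason for the step.

On these data alone, it remains open whether a carboxylic acid, a methyl ester or a longer ketone chain in place of acetyl would read like compound 4 or like compound 2. As far as these compounds go, it is also open whether an amine at this place would give a number beyond the scatter of either.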